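The source may hold more compounds than are shown below. What is called first, only, known or untested is meant among the compounds shown, and "the series" means these compounds.

Measured so far:
Compound 1 `O=C(O)c1ccc(NC(=O)[C@H](CC2CCCC2)n2cnc(S(=O)(=O)C3CC3)c2)nc1`: 0.6 10^-6 cm/s
Compound 2 `O=C(O)c1ccc(NC(=O)[C@H](CC2CCCC2)n2cnc(S(=O)(=O)C3CCC3)c2)nc1`: 0.5 10^-6 cm/s

For the measured compounds named here, in an ADME assay on MDCKII-LE cells (Canis lupus familiaris) for permeability (a lower number here means that the compound crosses the layer more slowly, a higher number that the compound crosses the layer faster), compound 1 holds the upper of only two numbers, but compound 2 lies within the scatter of it, so neither stands apart. Compound 3 `O=C(O)c1ccc(NC(=O)[C@H](CC2CCCCC2)n2cnc(S(=O)(=O)C3CC3)c2)nc1` has cyclohexyl in place of cyclopentyl on a saturated chain carbon, two bonds along the chain from an aromatic nitrogen and a carbonyl carbon. Going by the values given here, no measured step covers this place. Among the compounds with values here, the one measured step, cyclobutyl in place of cyclopropyl on a sulfonyl sulfur, bears on it only indirectly, as another change of saturated ring size: a 1.2-fold lower number from compound 1 to compound 2 (0.08 log units; within the scatter), within the scatter. Nothing beyond the scatter is therefore expected in this assay. The expected step is a 1.2-fold lower number from compound 1 to compound 3 (0.08 log units; within the scatter). For compound 3 the estimate is 0.5 10^-6 cm/s, with an expected range of 0.25 10^-6 cm/s to 1 10^-6 cm/s.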

Compound 3, apparent permeability: 0.5 10^-6 cm/s
Compound 3: middle estimate and measured number agree at the digits printed; the range from low to high includes it.
By their numbers in this assay, from the lowest: compounds 2, 3 and 1 (each within the scatter of the next).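

In this assay the ring on the saturated chain carbon now has a measured step of its own, cyclohexyl in place of cyclopentyl (a 1.2-fold lower number from compound 1 to compound 3 (0.08 log units; within the scatter)), whereas the earlier pair varied only the ring on the sulfonyl sulfur. Both ring-size steps now read, this one and the earlier one (a 1.2-fold lower number from compound 1 to compound 2 (0.08 log units; within the scatter)), stay within the scatter, at two different places on the core of compound 1, so for these three compounds neither change separates one number from another. No measured evidence is available that would account for this reading.

As far as these compounds go, what an amine-bearing ring such as piperidinyl, or a longer alkyl chain, would give at this place remains open. The carboxylic acid stands in all three compounds, so its share in these numbers cannot be read.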